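From 3-fluoro-4-methoxyphenyl to 3-chlorophenyl: an expected step

The source may hold more compounds than are shown below. What is called first, only, known or untested is meant among the compounds shown, and "the series" means these compounds.

Measured in a functional assay on NCI-H460 cells (Homo sapiens) for antiproliferative activity, read by MTT assay, with a stated time of 48 h; a lower number here means a stronger inhibitor, a higher number a weaker inhibitor:
Compound 1 `COc1ccc(-c2nc3cccc(-c4cc(OC)c(OC)c(OC)c4)c3o2)cc1`: 3500 nM
Compound 2 `COc1ccc(-c2nc3cccc(-c4cc(OC)c(OC)c(OC)c4)c3o2)cc1F`: 2800 nM
Compound 3 `COc1cc(-c2cccc3nc(-c4ccc(Br)cc4)oc23)cc(OC)c1OC`: > 25000 nM (a limit of the assay, not a number)

Among the compounds with values here, compound 2 gives 2800 nM, one of only two true numbers in this small set. The other is close to it: a 1.3-fold lower number from compound 1 to compound 2 (0.10 log units; within the scatter). The remaining entry sits well apart: an at least 8.9-fold higher number from compound 2 to compound 3 (0.95 log units; beyond the scatter).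

The next compound to be measured is compound 4 `COc1cc(-c2cccc3nc(-c4cccc(Cl)c4)oc23)cc(OC)c1OC`. It keeps the shared core of compound 2 and changes one group: 3-chlorophenyl in place of 3-fluoro-4-methoxyphenyl on an aromatic carbon. In words, 3-chlorophenyl stands in place of 3-fluoro-4-methoxyphenyl.

Two kinds of measured step bear on this change. Adding fluoro made no difference beyond the scatter, as a 1.3-fold lower number from compound 1 to compound 2 (0.10 log units; within the scatter) shows, so losing it should matter little. Losing the methoxy group mattered more: an at least 7.1-fold higher number from compound 1 to compound 3 (0.85 log units; beyond the scatter). Within the data shown here, that is the only measured example of such a loss, and it involves 4-bromophenyl rather than 3-chlorophenyl, so it may not carry over in full.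

A weaker inhibitor is therefore expected, with an estimated 3.6-fold higher number from compound 2 to compound 4 (0.55 log units; beyond the scatter). For compound 4 the estimate is 10000 nM, within an expected range of 3500 nM to 30000 nM.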

Compound 4, half-maximal inhibitory concentration: > 25000 nM
Compound 4: a limit, no number; the forecaster's own chance of this, stated with the estimate: 35%; at least 2.5-fold (0.39 log units) between middle value and limit.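

In this assay, 3-chlorophenyl in place of 3-fluoro-4-methoxyphenyl brings an at least 8.9-fold higher number from compound 2 to compound 4 (0.95 log units; beyond the scatter), and 3-chlorophenyl in place of 4-methoxyphenyl brings an at least 7.1-fold higher number from compound 1 to compound 4 (0.85 log units; beyond the scatter). The loss seen earlier with 4-bromophenyl is therefore not confined to that one group: among these four compounds, the two aryl groups that carry a methoxy group give true numbers, while the two without one, 4-bromophenyl and 3-chlorophenyl, both end at a limit of the assay. Both of those entries are limits, so the step between them cannot be read and the real losses may be larger than the printed sizes: the limit of > 25000 nM in this assay, at which 2 of the 4 values shown sit.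

As far as these compounds go, it remains open whether the methoxy group itself is what matters on this phenyl ring, a question that a hydroxy, ethoxy or dimethylamino group in its place could help to answer. From the compounds shown here alone, it is also open whether a phenyl ring without a methoxy group can give a true number at this position, for instance one carrying an amine or a carboxylic acid.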